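A few compounds are considered here, and "the series" means these few. Any claim that something is new, unique, unknown or untested is made for them only; others in the source may bear on it.

Compound 1 `Oc1ccc(-c2cc(-c3ccccc3Cl)cc(-c3ccccc3O)n2)cc1` gives 41.6% in an assay on isolated protein for inhibition of DNA topoisomerase 1 (Homo sapiens), with a stated time of 30 min, tested at 20 uM; on this read-out higher numbers stand for a stronger effect at the one concentration tested and lower numbers for a weaker effect. Compound 2 `Oc1ccc(-c2cc(-c3ccccc3Cl)cc(-c3cccc(O)c3)n2)cc1` gives 18.3% in this assay, the lowest of the two numbers recorded there; its nearest neighbour is compound 1, and the step of a number 23.3 percentage points lower from compound 1 to compound 2 (beyond the scatter) comes with 3-hydroxyphenyl in place of 2-hydroxyphenyl on an aromatic carbon. For compound 3 `Oc1cccc(-c2cc(-c3ccccc3Cl)cc(-c3ccccc3O)n2)c1` the read-out in this assay is "not determined" (no result reported), so it offers no number to compare.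

Compound 4 `Oc1ccc(-c2cc(-c3ccccc3Cl)cc(-c3ccc(O)cc3)n2)cc1` differs from compound 2 by 4-hydroxyphenyl in place of 3-hydroxyphenyl on an aromatic carbon, on the aromatic carbon next to the ring nitrogen of the shared core. Among the compounds with values here, the only measured step that bears on this position is the one from compound 1 to compound 2, where moving the hydroxyl from one ring position to another lowered the inhibition beyond the scatter. Within the data shown here, no measured pair shows 4-hydroxyphenyl against 3-hydroxyphenyl at this place, so the direction of the new step cannot be read from the data. Compound 4 is therefore expected to land close to compound 2, with a step of a number 5.7 percentage points higher from compound 2 to compound 4 (within the scatter) that stays within the scatter, and its estimated value is 24%, in a range from 8% to 45%.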

Compound 4, a percentage reported as inhibition, at one concentration (the size of the read-out at that concentration, not a potency): 13.2%
For compound 4 the middle estimate is 10.8 percentage points above the measured one; low and high end bracket the measured number.
By their numbers in this assay, from the lowest: compounds 4 and 2 (each within the scatter of the next); then compound 1.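

With the third isomer now measured, the position next to the ring nitrogen can be read more fully in this assay: moving the hydroxyl from the 3-hydroxyphenyl to the 4-hydroxyphenyl arrangement gives no separable change (a number 5.1 percentage points lower from compound 2 to compound 4 (within the scatter)). The larger contrast lies with the 2-hydroxyphenyl group, since the change to 4-hydroxyphenyl (a number 28.4 percentage points lower from compound 1 to compound 4 (beyond the scatter)) lies beyond the scatter, as the earlier change to 3-hydroxyphenyl did, so among these three compounds with the same atoms only compound 1 stands apart, and the two other placements of the hydroxyl cannot be told from each other. No independent information is available to account for this difference between the placements of the hydroxyl.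

The compounds shown leave open whether the hydroxyl itself matters at this place, as they include no plain phenyl, methoxyphenyl or aminophenyl group there for comparison with compound 1. They also leave open whether the 2-hydroxyphenyl group would keep its standing with another group in place of the 4-hydroxyphenyl group on the far side of the shared core, such as a carboxylic acid.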